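This account rests on a few compounds, and the source may have more. Where it says the series, first, only, none or still open, it means among the compounds named here.

Working notes on the series. Compound 1 `N#C[C@@H]1CCCN1C(=O)[C@@H]1C[C@H](C(=O)N2CCOCC2)CN1` in an assay on the whole organism (plasma, strain Sprague-Dawley) for inhibition of Dipeptidyl peptidase 4 (Rattus norvegicus), with a stated time of 10 h, at a dose of 1 mg/kg by the oral route (on this read-out lower numbers stand for less inhibition and higher numbers for more inhibition at the one dose given (going by the name of the read-out)), gives 44%. Compound 2 `N#C[C@@H]1CCCN1C(=O)[C@@H]1C[C@H](C(=O)N2CCCCCC2)CN1` in this assay gives "not determined" (no result reported), so it stands nowhere on the numbers shown. Compound 3 `N#C[C@@H]1CCCN1C(=O)[C@@H]1C[C@H](C(=O)N2CCC2)CN1` differs from compound 2 by azetidin-1-yl in place of azepan-1-yl on a carbonyl carbon. Among the measured compounds shown here, no measured pair bears on this change, and compound 1 offers only a single point of reference. In this assay a step from compound 2 to compound 3 is expected to be no larger than the usual scatter, with no direction favoured. Compound 3 is estimated at 40%, expected between 15% and 65%.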

Compound 3, a percentage reported as inhibition, in the whole organism at one dose (the size of the read-out at that dose, not a potency): 46%
Beside the measured number, compound 3's estimate is 6 percentage points below it, and the stated range covers the measured number.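

In this assay, among the compounds shown here, azetidin-1-yl in place of morpholin-4-yl on a carbonyl carbon gives a number 2 percentage points higher from compound 1 to compound 3 (within the scatter), the first step that can be read at this position. The two rings, which differ in size and in the ring oxygen of morpholin-4-yl, thus give values within the scatter of each other at this one dose. Nothing available explains this result.

Open, going by these compounds, is whether an open-chain dimethylamino group or a piperazin-1-yl ring with its free amine on the same carbonyl carbon would give a value within this same scatter.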